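The source may hold more compounds than are shown below. What is called first, only, known or untested is meant among the compounds shown, and "the series" means these compounds.

Measured in a functional assay on cells (Platelet, Homo sapiens) for inhibition; on this read-out higher numbers stand for weaker inhibition and lower numbers for stronger inhibition:
- Compound 1 `CCOC(=O)c1ccc(-c2nn(Cc3cccc(OC)c3)c3ccccc23)cc1` gives 260 nM
- Compound 2 `O=C(O)c1ccc(-c2nn(Cc3ccccc3)c3ccccc23)cc1` gives > 10000 nM as a limit

Compound 2 stands at > 10000 nM in this assay as a limit of the assay and not as a number. Among the measured compounds shown here, no two measured compounds differ in only one place, so no measured step can serve as a guide.

Compound 3 `CCNC(=O)c1ccc(-c2nn(Cc3ccccc3)c3ccccc23)cc1` has ethylamino in place of hydroxy on a carbonyl carbon and so goes from carboxy to ethylcarbamoyl. Compound 1, which has no carboxy, gives 260 nM in this assay, so a large move towards stronger inhibition is expected, though its size is very uncertain. The expected change is an at least 6.6-fold lower number from compound 2 to compound 3 (0.82 log units; beyond the scatter) in this estimate. Compound 3 is estimated at 1500 nM, with an expected range of 200 nM to 10000 nM in this assay.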

Compound 3, half-maximal inhibitory concentration: 5640 nM
Beside the measured number, compound 3's estimate is 3.8-fold (0.58 log units) below it; the measured number falls inside the stated range.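

In this assay, with the rest of the molecule unchanged, putting ethylamino in place of hydroxy on a carbonyl carbon, which turns carboxy into ethylcarbamoyl, gives an at least 1.7-fold lower number from compound 2 to compound 3 (0.24 log units; that floor lies within the scatter). Among the compounds shown here, this is the first pair that differs in only one place, and it shows that compound 3, which has no carboxy, still gives a measurable inhibition of 5640 nM. The true size of the step stays unknown because compound 2 stands at a limit of the assay and not at a number: the limit of > 10000 nM in this assay, at which 1 of the 3 values shown sits.

The compounds shown leave open how a plain amino group, or a longer chain such as butylamino, would read on this carbonyl carbon. Compound 1 differs from both compound 2 and compound 3 in more than one place, so it gives no clean comparison with either.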